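The source may report more compounds than this note shows. Statements on the series, on what has been measured and on what is new or still open speak of the compounds shown alone.

Measured compounds in a physicochemical assay for acid dissociation:

Compound 1 `CC(C)N(C1=NCCN1)c1c(Br)cccc1Br` gives 11.2
Compound 2 `CC(C)CN(C1=NCCN1)c1c(Br)cccc1Br` gives 11
Compound 3 `Brc1cccc(Br)c1N(CC1CCCC1)C1=NCCN1` gives 10.9

The three compounds share one core and differ only in the group on the nitrogen on the aromatic ring. Compound 1 stands nearest to compound 2, a number 0.20 log units lower from compound 1 to compound 2 (within the scatter), and furthest from compound 3, a number 0.30 log units lower from compound 1 to compound 3 (within the scatter); both of these steps are within the scatter, as is the one between the other two, a number 0.10 log units lower from compound 2 to compound 3 (within the scatter). None of the three groups, then, shifts the read-out by more than the repeat measurements themselves wander.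

Compound 4 `Brc1cccc(Br)c1N(CC1CCCCC1)C1=NCCN1` is the next member of this set. It differs from compound 1 as follows: cyclohexylmethyl in place of isopropyl on a nitrogen on an aromatic ring. Going by the values given here, the steps that bear on this change are those from compound 1 to compound 2 and from compound 1 to compound 3, where a larger chain or a chain carrying a ring took the place of isopropyl, and both stayed within the scatter. The ring in compound 4 is one carbon larger than that in compound 3, and nothing in the measured set suggests that this matters. Compound 4 is therefore expected to move from compound 1 by a number 0.30 log units lower from compound 1 to compound 4 (within the scatter), with no change beyond the scatter. The estimate for compound 4 is 10.9, between 10.6 and 11.2.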

Compound 4, acid dissociation constant: 11.2
Compound 4: middle estimate off by 0.30 log units, on the low side; the range from low to high includes it.
By their numbers in this assay, from the lowest: compounds 3, 2, 1 and 4 (each within the scatter of the next).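

In this assay, the widest replacement shown so far, cyclohexylmethyl with its six-membered ring of carbon only in place of isopropyl on a nitrogen on an aromatic ring, gives no change at the digits printed from compound 1 to compound 4 (within the scatter). The two other new steps, a number 0.30 log units higher from compound 3 to compound 4 (within the scatter) and a number 0.20 log units higher from compound 2 to compound 4 (within the scatter), also stay inside the scatter, so exchanging cyclopentyl or isopropyl for cyclohexyl on the saturated chain carbon leaves no measurable mark, and all four groups now form a single set with no order among them at this position. No supporting evidence bears on why this position tolerates such a change without a measurable shift.

All four groups are made of carbon alone, with no net charge and no hydrogen-bond donors or acceptors, so the compounds shown leave open whether a phenyl ring, or a chain carrying an amine, a hydroxyl or a carboxylic acid, would stay within the scatter at this nitrogen. They also leave open whether the same holds on a different core, since the shared core with its two bromines is the same throughout.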